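Butyl ester analogue of compound 2: expected cytotoxicity

The compounds below may be only part of what the source reports. "The series", "measured", "known", "first", "only" and "open" are said of these compounds alone.

Measured so far in a functional assay on HepG2 cells (Homo sapiens) for cytotoxicity, read by MTT assay, with a stated time of 48 h; a lower number here means a stronger inhibitor, a higher number a weaker inhibitor:
- compound 1 `COc1ccc(CN2C(=O)C(=O)c3cc(/C=C/C(=O)OC(C)(C)C)ccc32)cc1`: compound 1 gives 620 nM
- compound 2 `CC(C)(C)OC(=O)/C=C/c1ccc2c(c1)C(=O)C(=O)N2Cc1ccc(Br)cc1`: compound 2 gives 2050 nM
- compound 3 `COC(=O)/C=C/c1ccc2c(c1)C(=O)C(=O)N2Cc1ccc(Cl)c(Cl)c1`: compound 3 gives 160 nM

Compound 2 gives the highest number of the three in this assay. Among the compounds with values here, the nearest is compound 1, and the one measured step in the set, a 3.3-fold higher number from compound 1 to compound 2 (0.52 log units; beyond the scatter), is a modest move beyond the scatter that separates these two. Compound 3 stands furthest from compound 2 on the numbers, but it differs from compound 2 in more than one place, so only the two values can be compared.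

Compound 4 `CCCCOC(=O)/C=C/c1ccc2c(c1)C(=O)C(=O)N2Cc1ccc(Br)cc1` is not yet measured. The change from compound 2 reads (butyl in place of tert-butyl on an oxygen next to a carbonyl group), a rearrangement of the same atoms on an oxygen next to a carbonyl group. Within the data shown here, no measured step touches the ester group; the only step known, a 3.3-fold higher number from compound 1 to compound 2 (0.52 log units; beyond the scatter), concerns a substituent on the benzyl ring and does not bear on this change. With nothing to point either way, no step beyond the scatter is expected, and a 1.1-fold lower number from compound 2 to compound 4 (0.06 log units; within the scatter) is the estimate. Compound 4 is therefore expected at about 1800 nM, within 700 nM to 4500 nM.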

Compound 4, half-maximal inhibitory concentration: 650 nM
Beside the measured number, compound 4's estimate is 2.8-fold (0.44 log units) above it; the whole stated range lies above it.
By their numbers in this assay, from the lowest: compound 3; then compounds 1 and 4 (each within the scatter of the next); then compound 2.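

Swapping tert-butyl for butyl on an oxygen next to a carbonyl group, with the same atoms joined differently, gives a 3.2-fold lower number from compound 2 to compound 4 (0.50 log units; beyond the scatter) in this assay and is the first measured step at the ester. Until now the only single-place step lay on the benzyl ring, a 3.3-fold higher number from compound 1 to compound 2 (0.52 log units; beyond the scatter), so the ester alkyl group is now shown to matter as well, at least for the bromo compounds. No measurement shown explains why the butyl and tert-butyl esters differ.

On these data alone, it remains open whether a longer chain or a free carboxylic acid at this position would move the number further in the same direction. As far as these compounds go, it is also open whether the butyl for tert-butyl step would hold with the methoxy group of compound 1 on the benzyl ring.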